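Swapping the Amine Tail: From Compound 2 to Compound 3

This account rests on a few compounds, and the source may have more. Where it says the series, first, only, none or still open, it means among the compounds named here.

Measured so far:
compound 1, `CC(=O)Oc1ccccc1C1CC(C)=NN1C(=O)CN1CCC(C(C)=O)CC1`: 4120 nM
compound 2, `CCNCC(=O)N1N=C(c2cc3ccccc3oc2=O)CC1c1ccccc1`: 26600 nM

Of the compounds shown here, two have been measured in a functional assay on MGC-803 cells (Homo sapiens) for cytotoxicity, read by MTT assay, with a stated time of 48 h; a higher number here means a weaker inhibitor, a lower number a stronger inhibitor. Compound 1 gives 4120 nM. Compound 2 gives 26600 nM, the higher of the two numbers, and its gap to compound 1 lies beyond the usual scatter of this assay. Compound 3, `O=C(CN1CCC(O)CC1)N1N=C(c2cc3ccccc3oc2=O)CC1c1ccccc1`, has not been measured yet. It differs from compound 2 in a single place: 4-hydroxypiperidin-1-yl in place of ethylamino on a saturated chain carbon bound to a carbonyl carbon. Everything else in the two structures is the same. Within the data shown here, no measured pair shows this exact change, so the expectation rests only on the two numbers above and on the nature of the change itself. The step is expected to be modest and to run toward a lower number, with the estimated step of a 2.2-fold lower number from compound 2 to compound 3 (0.35 log units; beyond the scatter) reaching just past the scatter. Compound 3 is therefore estimated at 12000 nM, within a range from 4000 nM to 40000 nM.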

Compound 3, half-maximal inhibitory concentration: "not active" (no number reported)
For compound 3 the study gives words and no number; the estimate stays without a comparison.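

In this assay, among these compounds, compound 3 is reported only in words, as not active, so no step from compound 2 to compound 3 can be read. Nothing available bears on this result. The compounds shown leave open how far replacing ethylamino with 4-hydroxypiperidin-1-yl moves the number.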